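The compounds below may be only part of what the source reports. "The series", "measured", "known", "first", "only" and "open" are said of these compounds alone.

Three compounds of a shared core have been examined in an ADME assay on L6 cells (Rattus norvegicus) for cytotoxicity, read by resazurin assay, with a stated time of 72 h (on this read-out higher numbers stand for weaker inhibition and lower numbers for stronger inhibition), and a fourth awaits measurement. Compound 1, `CN1CCN(CCC(=O)NC2CC3(N(C)C)CC(c4ccccc4)C2C(c2ccccc2)C3)CC1`, gives 95000 nM in this assay. Compound 2, `CN1CCN(CC(=O)N2CCC3(N(C)C)CC(c4ccccc4)C2C(c2ccccc2)C3)CC1`, gives 195000 nM, and compound 3, `CN1CCN(CC(=O)N2CCC3(N4CCCCC4)CC(c4ccccc4)C2C(c2ccccc2)C3)CC1`, gives 177000 nM. The difference between the core of compound 1 and the core of compound 2 is not broken down here.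

Compound 3 is made from compound 2 by one change, (piperidin-1-yl in place of dimethylamino on a saturated ring carbon), and this gave a 1.1-fold lower number from compound 2 to compound 3 (0.04 log units; within the scatter) in this assay. The unmeasured compound 4, `CN1CCN(CCC(=O)NC2CC3(N4CCCCC4)CC(c4ccccc4)C2C(c2ccccc2)C3)CC1`, is related to compound 1 by the same kind of change, (piperidin-1-yl in place of dimethylamino on a saturated ring carbon). The surroundings of the place differ, however: in compound 1 the ring carbon sits with two ring bonds from the ring atom that bears a large group and two ring bonds from the ring atom that bears a phenyl group, whereas in compound 2 it sits with two ring bonds from two ring atoms that each bear a phenyl group.

Because the earlier step of a 1.1-fold lower number from compound 2 to compound 3 (0.04 log units; within the scatter) stayed within the scatter, the step from compound 1 to compound 4 in this assay is expected to be of similar size, namely a 1.1-fold lower number from compound 1 to compound 4 (0.05 log units; within the scatter). On that basis compound 4 is estimated to give 85000 nM in this assay, with a range from 40000 nM to 180000 nM expected.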

Compound 4, half-maximal inhibitory concentration: 61100 nM
Beside the measured number, compound 4's estimate is 1.4-fold (0.14 log units) above it; measured number inside the range.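

The new step on the core of compound 1, piperidin-1-yl in place of dimethylamino on a saturated ring carbon, is a 1.6-fold lower number from compound 1 to compound 4 (0.19 log units; within the scatter) in this assay. Set beside the earlier step on the other core, the change behaves alike on both cores, with no difference that can be told apart from the scatter: the same change on two cores in this assay, a 1.1-fold lower number (0.04 log units; within the scatter) from compound 2 to compound 3 and a 1.6-fold lower number (0.19 log units; within the scatter) from compound 1 to compound 4, 1.4-fold (0.15 log units) apart, within the scatter of two such steps This shows that, on these two cores and in this one assay, the exchange of dimethylamino for piperidin-1-yl left the number within the scatter despite the different surroundings of the ring carbon; it does not show that the change would carry over in the same way to any further core, and two small steps cannot exclude a modest difference between cores.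

The compounds shown leave open whether the same holds for other groups on that saturated ring carbon, such as morpholin-4-yl, a primary amine or a hydroxyl group. They also leave open whether the step stays this small when a longer chain replaces the side chain that carries the amide carbonyl on the core of compound 1.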